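Two Inactive Amides and a Chlorophenyl Replacement

This account rests on a few compounds, and the source may have more. Where it says the series, first, only, none or still open, it means among the compounds named here.

Measured so far:
Compound 1 `CS(=O)(=O)c1ccc(C(=O)Nc2ccc(Cl)c(-c3nnc4c(Cl)cccn34)c2)c(Cl)c1` — in this assay compound 1 gives > 100000 nM, a limit of the assay rather than a number.
Compound 2 `Cc1nc(C(=O)Nc2ccc(Cl)c(-c3nnc4c(Cl)cccn34)c2)cs1` — compound 2 gives > 100000 nM, likewise a limit and not a number.

Both compounds were tested in a functional assay on AN3-CA cells (Homo sapiens) for antiproliferative activity, read by MTT assay, with a stated time of 72 h; on this read-out lower numbers stand for stronger inhibition and higher numbers for weaker inhibition. Going by the values given here, neither reading is a measured number: compound 2 stands only at a limit, and the one other value shown is a limit as well, so nothing here orders the two compounds against each other (the limit of > 100000 nM in this assay, at which 2 of the 2 values shown sit). Among the compounds with values here, no step between measured compounds can be drawn from this, and no change in either direction is established.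

Compound 3 `O=C(Nc1ccc(Cl)c(-c2nnc3c(Cl)cccn23)c1)c1ccccc1Cl` is the next compound and has not yet been measured in this assay. It differs from compound 2 in a single place: 2-chlorophenyl in place of 2-methyl-1,3-thiazol-4-yl on a carbonyl carbon. The change swaps one aromatic ring bearing the carbonyl for another, while the shared core stays untouched.

With both measured values resting at a limit, the step that the limit leaves unreadable from compound 2 to compound 3 is expected to be none beyond the usual scatter. Compound 3 is therefore estimated at 150000 nM, with a range from 30000 nM to 600000 nM, and most likely it will again be reported only as a limit.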

Compound 3, half-maximal inhibitory concentration: > 100000 nM
Compound 3: a limit, no number; the forecaster's own chance of this, stated with the estimate: 75%; the middle value lies beyond the limit too.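

In this assay compound 3 gives > 100000 nM, again a limit and not a number. No step from compound 1 or compound 2 to compound 3 can be read, because all three sit at the same limit: the limit of > 100000 nM in this assay, at which 3 of the 3 values shown sit.

The compounds shown leave open whether any group on this carbonyl carbon gives a measurable value.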